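A few compounds are considered here, and "the series" means these few. Any claim that something is new, unique, unknown or untested is made for them only; others in the source may bear on it.

Working notes on the series. Compound 2 `Cc1cc(CC(C)C(=O)O)ccc1-c1noc(-c2ccc(OC(C)C)c(C(F)(F)F)c2)n1` and its neighbour compound 1 `Cc1cc([C@@H]2C[C@H]2C(=O)O)ccc1-c1noc(-c2ccc(OC(C)C)c(C(F)(F)F)c2)n1` share one core and differ only in the acid-bearing chain. In an assay on CHO cells for displacement of a labelled ligand from sphingosine 1-phosphate receptor 4 (Homo sapiens) (on this read-out lower numbers stand for stronger inhibition and higher numbers for weaker inhibition), compound 1 gives > 10000 nM, which is a limit of the assay and not a number. In this assay compound 2 likewise gives > 10000 nM, again a limit. The step that the two limits leave unreadable from compound 1 to compound 2 is therefore not readable, and compound 2 stands with its value (the limit of > 10000 nM in this assay, at which 2 of the 2 values shown sit).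

Compound 3 `Cc1cc(CCC(=O)O)ccc1-c1noc(-c2ccc(OC(C)C)c(C(F)(F)F)c2)n1` differs from compound 2 by hydrogen in place of methyl on a saturated chain carbon bound to a carbonyl carbon and a saturated chain carbon. Within the data shown here, only one measured step bears on this change, the unreadable one from compound 1 to compound 2, so no direction beyond the scatter can be read for this assay. The expected step that the limit leaves unreadable from compound 2 to compound 3 from compound 2 to compound 3 therefore rests on both neighbours sitting at the limit. For compound 3 the estimate is 20000 nM, in the range 4000 nM to 100000 nM.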

Compound 3, half-maximal inhibitory concentration: > 10000 nM
Compound 3: a limit, no number; the forecaster's own chance of this, stated with the estimate: 85%; the middle value lies beyond the limit too.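

In this assay compound 3 gives > 10000 nM, a limit of the assay and not a number. Among these compounds, no step between compound 1, compound 2 and compound 3 can therefore be read. The compounds shown leave open whether the acid-bearing chain affects inhibition at all: the limit of > 10000 nM in this assay, at which 3 of the 3 values shown sit.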